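A few compounds are considered here, and "the series" means these few. Any claim that something is new, unique, unknown or untested is made for them only; others in the source may bear on it.

Compound 1 `O=C(Nc1ccccc1Br)c1ccc2cccc(O)c2n1` is examined in an ADME assay on THP-1 cells (Homo sapiens) for cytotoxicity, read by WST assay, with a stated time of 24 h; a higher number here means a weaker inhibitor, a lower number a stronger inhibitor. In this assay compound 1 gives > 30000 nM, which is a limit of the assay rather than a number. Compound 2 `O=C(Nc1cccc(Br)c1)c1ccc2cccc(O)c2n1` differs from compound 1 by 3-bromophenyl in place of 2-bromophenyl on an amide-type nitrogen. In this assay compound 2 gives > 30000 nM, again a limit. Compound 3 `O=C(Nc1ccccc1C(F)(F)F)c1ccc2cccc(O)c2n1` carries trifluoromethyl in place of bromo on an aromatic carbon. In this assay compound 3 gives > 30000 nM, also a limit. Hence a step that the two limits leave unreadable from compound 1 to compound 2 and a step that the two limits leave unreadable from compound 1 to compound 3, and everything seen so far rests on (the limit of > 30000 nM in this assay, at which 3 of the 3 values shown sit). Compound 4 `O=C(Nc1cccc(C(F)(F)F)c1)c1ccc2cccc(O)c2n1` is not yet measured; it carries trifluoromethyl in place of bromo on an aromatic carbon, the same kind of change as in compound 3, though there the place is ortho to a large group and here meta to a large group. Because compound 2 and compound 3 both sit at the limit of > 30000 nM in this assay, at which 3 of the 3 values shown sit, compound 4 is expected to give 60000 nM, an expected step that the limit leaves unreadable from compound 2 to compound 4.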

Compound 4, half-maximal inhibitory concentration: > 30000 nM
Compound 4 ended at the assay's limit (the forecaster's own chance of this, stated with the estimate: 85%); the middle value lies beyond the limit too.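

No step can be read between compound 2 and compound 4, because both values are limits of the assay and not numbers: the limit of > 30000 nM in this assay, at which 4 of the 4 values shown sit.

The compounds shown leave open what value any of the four compounds would give beyond that limit.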